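A few compounds are considered here, and "the series" means these few. Any claim that something is new, unique, unknown or untested is made for them only; others in the source may bear on it.

Measured in a functional assay on MC-38 cells (Mus musculus) for antiproliferative activity, read by colorimetric assay and MTT assay; on this read-out higher numbers stand for weaker inhibition and lower numbers for stronger inhibition:
- compound 1 `O=S(=O)(Nc1cccc2c(Cl)c[nH]c12)c1ccc(Cl)cc1`: 0.28 ug/mL
- compound 2 `O=[N+]([O-])c1ccc(S(=O)(=O)Nc2cccc3cc[nH]c23)cc1`: 7.2 ug/mL
- compound 3 `O=[N+]([O-])c1ccc(S(=O)(=O)Nc2cccc3c(Cl)c[nH]c23)cc1`: 0.34 ug/mL

Compound 3, at 0.34 ug/mL, sits with compound 1 at the low end of these three numbers, while compound 2 stands alone at the high end. Next is compound 4 `N#Cc1ccc(S(=O)(=O)Nc2cccc3c(Cl)c[nH]c23)cc1`, which differs from compound 3 by a single change: cyano in place of nitro on an aromatic carbon, para to a large group (cyano in place of nitro on an aromatic carbon).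

Going by the values given here, two measured steps bear on this. The one closest in kind is nitro in place of chloro on an aromatic carbon, which gives a 1.2-fold higher number from compound 1 to compound 3 (0.08 log units; within the scatter). The other is chloro in place of hydrogen on an aromatic carbon, which gives a 21-fold lower number from compound 2 to compound 3 (1.33 log units; beyond the scatter). That large step concerns a group that compound 4 keeps, so it is not expected to be lost here. Among the compounds with values here, no measured compound carries cyano, and the evidence for the exchanged group rests on a single pair. With that caution, no step beyond the scatter is expected in this assay, and no direction is favoured with any confidence. The estimated step is a 1.2-fold higher number from compound 3 to compound 4 (0.07 log units; within the scatter). The estimate for compound 4 is 0.4 ug/mL, with an expected range of 0.15 ug/mL to 1.2 ug/mL.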

Compound 4, half-maximal inhibitory concentration: 0.13 ug/mL
Beside the measured number, compound 4's estimate is 3.1-fold (0.49 log units) above it; measured number below the stated range.
By their numbers in this assay, from the lowest: compound 4; then compounds 1 and 3 (each within the scatter of the next); then compound 2.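

In this assay, this place, on an aromatic carbon para to a large group, proves sensitive to the group it carries: chloro and nitro could not be told apart, but cyano separates from both, with a 2.6-fold lower number from compound 3 to compound 4 (0.42 log units; beyond the scatter) and a 2.2-fold lower number from compound 1 to compound 4 (0.33 log units; beyond the scatter). Both steps are modest and point the same way, towards stronger inhibition, and both are much smaller than a 21-fold lower number from compound 2 to compound 3 (1.33 log units; beyond the scatter), the chloro in place of hydrogen step on the core, which remains the largest effect in the series. Nothing measured here accounts for why cyano differs from nitro and chloro at this place.

Three groups at one place cannot show whether the shift towards stronger inhibition is particular to cyano or is shared by others there, such as a methoxy group, an amine or a carboxylic acid. Also open, going by these compounds, is whether cyano in place of nitro gives a similar step on the core of compound 2, which has hydrogen where compound 3 has chloro, or whether the two changes depend on each other.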